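This account rests on a few compounds, and the source may have more. Where it says the series, first, only, none or still open, it means among the compounds named here.

Compound 1 `c1coc(CNc2nc(NCCCN3CCCC3)nc3ccccc23)c1`, compound 2 `CCCCCNc1nc(NCc2ccco2)c2ccccc2n1` and compound 3 `CCN(CC)CCNc1nc(NCc2ccco2)c2cc(F)ccc2n1` share a core and differ in the amine chain and in one substituent on an aromatic carbon. In a functional assay on HCT-116 cells (Homo sapiens) for cytotoxicity, read by MTT assay, with a stated time of 2 days, tested at 10 uM (on this read-out lower numbers stand for less inhibition and higher numbers for more inhibition at the one concentration tested (going by the name of the read-out)), compound 1 gives 67.5%. For compound 2 the entry in this assay reads "not determined" (no result reported), so no result was reported. Compound 3 gives 26.4% in this assay, the lower of the two numbers available, and compound 1 stands higher by a gap that is beyond the usual scatter. Compound 4 `CCN(CC)CCNc1nc(NCc2ccco2)c2ccccc2n1` has not yet been measured. It differs from compound 3 in one place: hydrogen in place of fluoro on an aromatic carbon. The fluoro leaves from an aromatic carbon of a six-membered aromatic ring of carbon only, and a hydrogen enters. Among the compounds with values here, no pair of measured compounds shows this change on its own, so its effect in this assay cannot be read from a measured step. The change removes only one heavy atom, and the step expected here is a number 3.6 percentage points higher from compound 3 to compound 4 (within the scatter), a shift that may well stay within the scatter. Compound 4 is therefore estimated to give 30% in this assay, with a likely range from 10% to 55%.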

Compound 4, a percentage reported as inhibition, at one concentration (the size of the read-out at that concentration, not a potency): 50.3%
For compound 4 the middle estimate is 20.3 percentage points below the measured one; the range from low to high includes it.
By their numbers in this assay, from the lowest: compound 3; then compound 4; then compound 1.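

Hydrogen in place of fluoro on this aromatic carbon gives a number 23.9 percentage points higher from compound 3 to compound 4 (beyond the scatter) in this assay and is the first measured view of this position alone, with the fluoro compound showing less inhibition in this pair. Within the data shown here, compound 4 also connects the diethylamino chain to the chain of compound 1: diethylamino in place of (pyrrolidin-1-yl)methyl gives a number 17.2 percentage points lower from compound 1 to compound 4 (beyond the scatter) and shows that this end of the chain also shifts the read-out, even with no fluoro in either compound. Nothing available explains either step. From the compounds shown here alone, whether chloro or methoxy on the same aromatic carbon would behave like fluoro or like hydrogen stays open, as does whether the fluoro step would keep its size with the (pyrrolidin-1-yl)methyl chain. Going by these compounds, each number comes from one concentration, so the compounds' potencies also remain unknown.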